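The source may report more compounds than this note shows. Statements on the series, on what has been measured and on what is new or still open speak of the compounds shown alone.

Compound 2 `C[C@@H](O)[C@H](NC(=O)CN(c1ncnc2c1ncn2C1CCCCO1)C1CC1)C(=O)OCc1ccccc1` and compound 1 `O=C(OCc1ccccc1)[C@@H]1CCCN1C(=O)CN(c1nc(Cl)nc2[nH]cnc12)C1CC1` share a core carrying an amino-acid-like side chain, and both were tested in a functional assay on the whole organism (Tail, strain ICR) with Mus musculus as the target, in the tail flick test, with a stated time of 60 min, at a dose of 25 umol/kg by the oral route; a higher number here means a stronger effect of the compound at the dose given, a lower number a weaker effect. Compound 1 gives 34.4% in this assay, and compound 2 gives 28.4%; the gap between these two numbers lies within the usual scatter, so on the evidence at hand compound 2 cannot be told apart from compound 1. Compound 3 `CC(C)(C)OC(=O)NCCCC[C@H](NC(=O)CN(c1ncnc2c1ncn2C1CCCCO1)C1CC1)C(=O)OCc1ccccc1` has not yet been measured. It differs from compound 2 in one place: 4-((tert-butoxycarbonyl)amino)butyl in place of 1-hydroxyethyl on a saturated chain carbon bound to an amide-type nitrogen and a carbonyl carbon. For the measured compounds named here, no pair of measured compounds shows the effect of this change, so nothing in the data points one way or the other. The step of a number 1.4 percentage points lower from compound 2 to compound 3 (within the scatter) that is expected is therefore small, and it is not expected to go beyond the scatter in either direction. For compound 3 in this assay the expected activity is 27%, within a range from 12% to 42%.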

Compound 3, a percentage reported as activity, at one dose (the size of the read-out at that dose, not a potency): 32.7%
Compound 3: middle estimate off by 5.7 percentage points, on the low side; the range from low to high includes it.
By their numbers in this assay, from the lowest: compounds 2, 3 and 1 (each within the scatter of the next).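

Replacing 1-hydroxyethyl with 4-((tert-butoxycarbonyl)amino)butyl, on a saturated chain carbon bound to an amide-type nitrogen and a carbonyl carbon, gives a number 4.3 percentage points higher from compound 2 to compound 3 (within the scatter) in this assay. For the compounds shown here, this is the first comparison of compounds that differ in one place, and it shows that a group of 12 heavy atoms can stand where one of 3 stood without moving the read-out beyond the scatter at this single dose. No measurement here offers a reason for this result.

The compounds shown leave open whether a free amine at the end of the butyl chain, or a carboxylic acid there, would also stay within the scatter. They also leave open what a plain methyl at this position would do, and a single dose cannot show whether potency is the same.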